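Defluorination of the chlorofluorohydroxyphenyl ketone in a thiophene series

The source may report more compounds than this note shows. Statements on the series, on what has been measured and on what is new or still open speak of the compounds shown alone.

Measured compounds:
- compound 1 `Cc1ccc(S(=O)(=O)Nc2cccc(-c3ccc(C(=O)c4cc(F)c(F)c(O)c4F)s3)c2)cc1`: 0.1 nM
- compound 2 `O=C(c1ccc(-c2cccc(NS(=O)(=O)c3cccc(Cl)c3)c2)s1)c1cc(F)c(F)c(O)c1F`: 0.8 nM
- compound 3 `O=C(c1ccc(-c2cccc(NS(=O)(=O)c3ccccc3)c2)s1)c1c(F)ccc(O)c1Cl`: 15.6 nM

In an assay for inhibition of 17-beta-hydroxysteroid dehydrogenase type 1 (Homo sapiens), read by HPLC, in the presence of a further agent that is not named here (on this read-out higher numbers stand for weaker inhibition and lower numbers for stronger inhibition), compound 3 gives the highest number of the three, with compound 2 giving a number that is lower by a clear margin and compound 1 lower still. Among the measured compounds shown here, the one step that can be read within one structural change is an 8.0-fold higher number from compound 1 to compound 2 (0.90 log units; beyond the scatter), a change on the sulfonyl aryl group and not on the ketone-bearing ring.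

Compound 4 `O=C(c1ccc(-c2cccc(NS(=O)(=O)c3ccccc3)c2)s1)c1cccc(O)c1Cl` differs from compound 3 only on the ketone-bearing ring: hydrogen in place of fluoro on an aromatic carbon. For the measured compounds named here, no measured pair in this set carries the same change, and the two rings that differ between compound 2 and compound 3 also differ in more than one place, so that gap cannot be attributed to the fluoro alone. The expectation for compound 4 therefore rests on compound 3 alone, with a wide range on either side and no firm direction.

The step expected from compound 3 to compound 4 in this assay is a 1.9-fold higher number from compound 3 to compound 4 (0.28 log units; within the scatter), a small move toward a higher number that may not exceed the scatter. Compound 4 is thus estimated at 30 nM, within 8 nM to 120 nM.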

Compound 4, half-maximal inhibitory concentration: 20.3 nM
Compound 4: the middle estimate sits 1.5-fold (0.17 log units) above what was measured; measured number inside the range.
By their numbers in this assay, from the lowest: compound 1; then compound 2; then compounds 3 and 4 (each within the scatter of the next).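

In this assay the step from 2-chloro-6-fluoro-3-hydroxyphenyl to 2-chloro-3-hydroxyphenyl reads (a 1.3-fold higher number from compound 3 to compound 4 (0.11 log units; within the scatter)), so compound 3 and compound 4 cannot be told apart, and on this ring the fluoro group para to the hydroxy group can give way to hydrogen with no change beyond the scatter. Among the compounds shown here, this is the first single change on the ketone-bearing ring that can be read, as the earlier step concerned only the sulfonyl aryl group. Nothing on hand gives a measured basis for explaining this result.

Still open, from the compounds shown here alone, is whether hydrogen at this carbon would be read the same way on the more heavily fluorinated ketone-bearing ring of compound 1 and compound 2, since this step comes from a single pair with an unsubstituted phenyl on the sulfonyl sulfur. Also open, going by these compounds, is how a methoxy group, an amino group or a nitrile would read on this same aromatic carbon, and what would follow from replacing the chloro group or the hydroxy group on the ring.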